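Estimating compound 3 from the loss of its sugar unit

The source may hold more compounds than are shown below. What is called first, only, known or untested is meant among the compounds shown, and "the series" means these compounds.

Measured so far:
compound 1 `O=C1C=C(c2ccc(O)cc2O[C@@H]2O[C@H](CO)[C@@H](O)[C@H](O)[C@H]2O)C(Cc2ccc(O)cc2)O1`: 46.7 ug/mL
compound 2 `COc1ccc(C2=CC(=O)OC2Cc2ccc(O)cc2)c(O[C@@H]2O[C@H](CO)[C@@H](O)[C@H](O)[C@H]2O)c1`: 61.4 ug/mL

Of the compounds shown here, two have been tested in a physicochemical assay, with a stated time of 6 min; on this read-out lower numbers stand for stronger inhibition and higher numbers for weaker inhibition. Compound 1 `O=C1C=C(c2ccc(O)cc2O[C@@H]2O[C@H](CO)[C@@H](O)[C@H](O)[C@H]2O)C(Cc2ccc(O)cc2)O1` gives 46.7 ug/mL, and compound 2 `COc1ccc(C2=CC(=O)OC2Cc2ccc(O)cc2)c(O[C@@H]2O[C@H](CO)[C@@H](O)[C@H](O)[C@H]2O)c1` gives 61.4 ug/mL. Compound 1 has the lower of the two numbers, but the step of a 1.3-fold higher number from compound 1 to compound 2 (0.12 log units; within the scatter) lies within the scatter, so the two compounds cannot really be told apart on this read-out.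

Compound 3 `O=C1C=C(c2ccc(O)cc2O)C(Cc2ccc(O)cc2)O1` has not been measured. It differs from compound 1 in one place: hydrogen in place of 3,4,5-trihydroxy-6-(hydroxymethyl)oxan-2-yl on an oxygen on an aromatic ring. For the measured compounds named here, the only measured step, a 1.3-fold higher number from compound 1 to compound 2 (0.12 log units; within the scatter), concerns a different change at a different oxygen and was within the scatter; no measured step covers the loss of the 3,4,5-trihydroxy-6-(hydroxymethyl)oxan-2-yl group. The direction of the step is therefore open, and only a modest change is expected. The number for compound 3 is estimated at 30 ug/mL, with a range of 12 ug/mL to 80 ug/mL. This means an expected step of a 1.6-fold lower number from compound 1 to compound 3 (0.19 log units; within the scatter).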

Compound 3, half-maximal inhibitory concentration: 28.3 ug/mL
Estimate against measurement, compound 3: 1.1-fold (0.03 log units) above, within the range that was stated.
By their numbers in this assay, from the lowest: compounds 3, 1 and 2 (each within the scatter of the next, the first and the last beyond it).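

In this assay, replacing the 3,4,5-trihydroxy-6-(hydroxymethyl)oxan-2-yl group on the oxygen on the aromatic ring with hydrogen gives a 1.7-fold lower number from compound 1 to compound 3 (0.22 log units; within the scatter), so this read-out does not separate the compound carrying the sugar unit from the compound without it. For the compounds shown here, the earlier step concerned a methyl on a different oxygen, so this is the first look at this position, and it shows that a group of 11 heavy atoms with 5 defined stereocentres can leave without a step beyond the scatter. No available measurement bears on what lies behind this result.

The compounds shown give this oxygen only two substituents, hydrogen and the sugar unit, which leaves open what a methyl, a longer alkyl chain or a chain ending in a carboxylic acid or an amine would do at the same place. They also leave open whether losing the sugar unit from compound 2, which carries a methyl on its other oxygen, would give a step of similar size.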